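This account rests on a few compounds, and the source may have more. Where it says the series, first, only, none or still open, it means among the compounds named here.

Compound 1 `O=C(/C=C/c1ccccc1F)Nc1ccc(CC2=CC(=O)OC2)cc1` heads this pair. In a functional assay on MCF7 cells (Homo sapiens) for cytotoxicity, read by MTT assay, with a stated time of 48 h (a higher number here means a weaker inhibitor, a lower number a stronger inhibitor), compound 1 gives > 50000 nM, which is a limit of the assay and not a number, and it sits at the limit of > 50000 nM in this assay, at which 1 of the 2 values shown sits. Compound 2 `C=C1OC(=O)C=C1Cc1ccc(NC(=O)/C=C/c2ccc(F)cc2)cc1` is measured in this assay at 4430 nM. Compound 3 `O=C(/C=C/c1cccc(F)c1)Nc1ccc(CC2=CC(=O)OC2)cc1` awaits measurement and differs from compound 1 by 3-fluorophenyl in place of 2-fluorophenyl on a double-bonded chain carbon bound to a double-bonded chain carbon. As compound 1 stands only at a limit, the size of this step is not fixed by the data. The expected step is an at least 2.5-fold lower number from compound 1 to compound 3 (0.39 log units; beyond the scatter), toward stronger inhibition, though uncertain. For compound 3 the estimate in this assay is 20000 nM, between 6000 nM and 50000 nM, with a real chance that only a limit is again reported.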

Compound 3, half-maximal inhibitory concentration: 39000 nM
Beside the measured number, compound 3's estimate is 2.0-fold (0.29 log units) below it, and the stated range covers the measured number.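

With 3-fluorophenyl in place of 2-fluorophenyl, this position now gives a measured number rather than a limit in this assay, with a step of an at least 1.2-fold lower number from compound 1 to compound 3 (0.10 log units; that floor lies within the scatter). Compound 1 gives > 50000 nM, which is a limit of the assay and not a number. The step therefore has only a floor, and its true size remains unfixed: the limit of > 50000 nM in this assay, at which 1 of the 3 values shown sits.

From the compounds shown here alone, whether a plain phenyl or a 3-chlorophenyl in this place would give a lower number than compound 3 remains open. Going by these compounds, how a 3-methoxyphenyl would read here also remains open.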